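A few compounds are considered here, and "the series" means these few. Any claim that something is new, unique, unknown or untested is made for them only; others in the source may bear on it.

Within the data shown here, in a physicochemical assay for lipophilicity, using the shake flask method (a lower number here means a more polar compound, a higher number a more lipophilic compound), compound 2 `C[C@H](Oc1ccc(/C=C/C(=O)O)cc1)c1c(Cl)ccc(F)c1Cl` gives 2.8, the lower of the two numbers so far, while compound 1 `Cc1cc(O[C@@H](C)c2c(Cl)ccc(F)c2Cl)ccc1/C=C/C(=O)O` stands at 3.2. The next compound, compound 3 `C[C@H](Oc1ccc(/C=C/C(=O)O)c(C2CC2)c1)c1c(Cl)ccc(F)c1Cl`, differs from compound 2 in one place: cyclopropyl in place of hydrogen on an aromatic carbon. This is cyclopropyl in place of hydrogen on an aromatic carbon, ortho to a 2-carboxyethenyl group.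

Among the measured compounds shown here, only one measured step bears on this change: a number 0.40 log units lower from compound 1 to compound 2 (beyond the scatter). There, hydrogen takes the place of methyl on an aromatic carbon, and the step is modest but beyond the scatter. Compound 1 carries that methyl ortho to the 2-carboxyethenyl group, so read in reverse, the step shows a hydrogen replaced by a carbon substituent and a higher number in this assay. For the measured compounds named here, no measured compound yet carries cyclopropyl, so the size of the new step rests on this single comparison and remains uncertain.

A rise somewhat larger than the methyl step is expected, given the additional carbon in the entering group. The expected change is a number 0.70 log units higher from compound 2 to compound 3 (beyond the scatter). Compound 3 is estimated at 3.5, within an expected range of 3.1 to 3.9.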

Compound 3, distribution coefficient: 3.6
The estimate for compound 3 lay 0.10 log units below the measured number; measured number inside the range.
By their numbers in this assay, from the lowest: compound 2; then compound 1; then compound 3.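

Cyclopropyl on this aromatic carbon, ortho to a 2-carboxyethenyl group, gives in this assay a number 0.80 log units higher from compound 2 to compound 3 (beyond the scatter) and so moves the number further than the earlier compounds had shown for this position. The position also has room to change beyond methyl: replacing methyl with cyclopropyl gives a number 0.40 log units higher from compound 1 to compound 3 (beyond the scatter) and carries compound 3 past compound 1, so that hydrogen, methyl and cyclopropyl now stand in rising order with no compound among these three against that order. Nothing measured here explains why the number moves in this way.

Three substituents at one position cannot show whether the ring of cyclopropyl matters or only its carbons, and an open chain such as ethyl or isopropyl would be needed to separate the two, while an amine or a methoxy group at the same carbon would show whether the order extends beyond hydrocarbon groups. As far as these compounds go, it also remains open whether cyclopropyl gives a similar step on another carbon of this aromatic ring, or on a core in which an amide takes the place of the carboxylic acid.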